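Plasma half-life of the ester series: compound 4

The source may report more compounds than this note shows. Statements on the series, on what has been measured and on what is new or still open speak of the compounds shown alone.

Compound 3 `NCc1ccc(C(=O)Nc2ccncc2F)cc1-c1cccc(C(=O)OCCO)c1` gives the highest number of the three measured, with 1.35 h in an ADME assay on a cell-free system (plasma, Homo sapiens) for metabolic stability, read by LC-MS; on this read-out lower numbers stand for a shorter-lived compound and higher numbers for a longer-lived compound; compound 2 `NCc1ccc(C(=O)Nc2ccncc2F)cc1-c1cccc(C(=O)OC2CCCOC2)c1` gives 0.3 h and compound 1 `CC(C)OCCOC(=O)c1cccc(-c2cc(C(=O)Nc3ccncc3F)ccc2CN)c1` gives 0.1 h. The step to compound 4 `NCc1ccc(C(=O)Nc2ccncc2F)cc1-c1cccc(C(=O)OCC2CCCC2)c1` is cyclopentyl in place of hydroxymethyl on a saturated chain carbon bound to an oxygen next to a carbonyl group. Going by the values given here, two measured steps bear on it, both at the oxygen next to the carbonyl group: a 14-fold higher number from compound 1 to compound 3 (1.13 log units; beyond the scatter) and a 4.5-fold higher number from compound 2 to compound 3 (0.65 log units; beyond the scatter). Both run toward the 2-hydroxyethyl ester; compound 4 runs the other way, into cyclopentylmethyl, so a lower number is expected, and compounds 1 and 2 suggest a modest to large fall. The expected step is a 5.4-fold lower number from compound 3 to compound 4 (0.73 log units; beyond the scatter). Compound 4 is therefore estimated at 0.25 h, within 0.08 h to 0.8 h.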

Compound 4, half-life: 0.283 h
Beside the measured number, compound 4's estimate is 1.1-fold (0.05 log units) below it, and the stated range covers the measured number.
By their numbers in this assay, from the lowest: compound 1; then compounds 4 and 2 (each within the scatter of the next); then compound 3.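

In this assay, cyclopentyl in place of hydroxymethyl on a saturated chain carbon bound to an oxygen next to a carbonyl group gives a 4.8-fold lower number from compound 3 to compound 4 (0.68 log units; beyond the scatter) and leaves compound 3 highest of the four. The cyclopentylmethyl and oxan-3-yl esters stand level, with a 1.1-fold lower number from compound 2 to compound 4 (0.03 log units; within the scatter) as the step between them. Cyclopentylmethyl still compares well with 2-isopropoxyethyl, giving a 2.8-fold higher number from compound 1 to compound 4 (0.45 log units; beyond the scatter) as its step.

Nothing available explains these steps. Still open, as far as these compounds go, is how a 3-hydroxypropyl ester, a longer chain ending in hydroxyl, or an amide in place of the ester would compare with compound 3.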